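The compounds below may be only part of what the source reports. "The series", "measured", "known", "first", "only" and "open" are said of these compounds alone.

Measured compounds, with the values they give in an ADME assay on L02 cells (Homo sapiens) for cytotoxicity, read by MTT assay, with a stated time of 48 h; a higher number here means a weaker inhibitor, a lower number a stronger inhibitor:
compound 1 `O=c1ccoc2cc(OCc3cn(Cc4cccc(F)c4)nn3)ccc12` gives > 300000 nM, which is a limit of the assay.
compound 2 `O=c1ccoc2cc(OCc3cn(Cc4cccc(Cl)c4)nn3)ccc12` gives > 300000 nM, which is a limit of the assay.
compound 3 `O=c1ccoc2cc(OCc3cn(Cc4ccccc4Cl)nn3)ccc12` gives > 300000 nM, which is a limit of the assay.

Compound 4 `O=c1ccoc2cc(OCc3cn(Cc4ccccc4F)nn3)ccc12` is not yet measured in this assay. From compound 3 to compound 4 the change is fluoro in place of chloro on an aromatic carbon. The same change occurs once more among these compounds, from compound 2 to compound 1: fluoro in place of chloro on an aromatic carbon, giving a step that the two limits leave unreadable from compound 2 to compound 1. The two places differ in their printed words, ortho to a large group in compound 4 against meta to a large group in compound 1, so this is the same kind of change rather than the same. The two cores differ by 2-chlorophenyl in place of 3-chlorophenyl on a saturated chain carbon bound to an aromatic nitrogen, with a step that the two limits leave unreadable from compound 2 to compound 3; likewise a step that the two limits leave unreadable from compound 1 to compound 3. All three values sit at the limit of > 300000 nM in this assay, at which 3 of the 3 values shown sit. For compound 4 the step is expected to be a number no higher from compound 3 to compound 4 (the limit leaves the size open), resting on the earlier step that the two limits leave unreadable from compound 2 to compound 1. Compound 4 is accordingly estimated at 300000 nM, within 100000 nM to 1000000 nM.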

Compound 4, half-maximal inhibitory concentration: > 300000 nM
Compound 4: no number, only a limit; the forecaster's own chance of this, stated with the estimate: 85%; the middle value sits exactly at the limit.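

In this assay, for the compounds shown here, compound 4 gives > 300000 nM, a limit of the assay, so no step from compound 1, compound 2 or compound 3 to compound 4 can be read. The compounds shown leave open whether fluoro in place of chloro changes cytotoxicity at all.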